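Methoxy addition on a coumarin hydrazone cyanoacrylamide series

This account rests on a few compounds, and the source may have more. Where it says the series, first, only, none or still open, it means among the compounds named here.

Measured so far:
compound 1 `C/C(=N\NC(=O)/C(C#N)=C/c1ccc(O)cc1)c1c(O)c2ccc(O)cc2oc1=O` — 61300 nM
compound 2 `COc1cc(/C=C(\C#N)C(=O)N/N=C(\C)c2c(O)c3ccc(O)cc3oc2=O)ccc1O` — 55400 nM
compound 3 `COc1ccc(/C=C(\C#N)C(=O)N/N=C(\C)c2c(O)c3ccc(O)cc3oc2=O)cc1OC` — 45300 nM

Compound 1 is `C/C(=N\NC(=O)/C(C#N)=C/c1ccc(O)cc1)c1c(O)c2ccc(O)cc2oc1=O`; in a functional assay on NRK-49F cells (Rattus norvegicus) for cytotoxicity, read by MTT assay, with a stated time of 24 h (on this read-out higher numbers stand for weaker inhibition and lower numbers for stronger inhibition), compound 1 gives 61300 nM. Compound 2 is `COc1cc(/C=C(\C#N)C(=O)N/N=C(\C)c2c(O)c3ccc(O)cc3oc2=O)ccc1O` and gives 55400 nM; compound 3 is `COc1ccc(/C=C(\C#N)C(=O)N/N=C(\C)c2c(O)c3ccc(O)cc3oc2=O)cc1OC` and gives 45300 nM. The three numbers lie close together: a 1.1-fold lower number from compound 1 to compound 2 (0.04 log units; within the scatter), a 1.2-fold lower number from compound 2 to compound 3 (0.09 log units; within the scatter), and a 1.4-fold lower number from compound 1 to compound 3 (0.13 log units; within the scatter).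

Compound 4, `COc1cc(/C=C(\C#N)C(=O)N/N=C(\C)c2c(O)c3ccc(O)cc3oc2=O)cc(OC)c1OC`, is not yet measured. It differs from compound 3 by methoxy in place of hydrogen on an aromatic carbon. The same kind of change links compound 1 to compound 2, (methoxy in place of hydrogen on an aromatic carbon), where it produced a 1.1-fold lower number from compound 1 to compound 2 (0.04 log units; within the scatter). The two cores differ by 3,4-dimethoxyphenyl in place of 4-hydroxyphenyl on a double-bonded chain carbon bound to a double-bonded chain carbon. The surroundings are not the same: in compound 1 the entering methoxy sits ortho to a hydroxy group and meta to a large group, while in compound 3 it sits ortho to a methoxy group, meta to a large group and meta to a methoxy group, so this is the same kind of change rather than the same change.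

Because the earlier step of a 1.1-fold lower number from compound 1 to compound 2 (0.04 log units; within the scatter) stayed within the scatter, the expected step from compound 3 to compound 4 is a 1.1-fold lower number from compound 3 to compound 4 (0.05 log units; within the scatter), also within the scatter. Compound 4 is therefore estimated at 40000 nM, between 20000 nM and 80000 nM.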

Compound 4, half-maximal inhibitory concentration: 55300 nM
The estimate for compound 4 lay 1.4-fold (0.14 log units) below the measured number; the measured number falls inside the stated range.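

Methoxy in place of hydrogen on an aromatic carbon gave, in this assay, a 1.2-fold higher number from compound 3 to compound 4 (0.09 log units; within the scatter). Set beside the earlier case, the change reads alike on the two cores: the same change on two cores in this assay, a 1.1-fold lower number (0.04 log units; within the scatter) from compound 1 to compound 2 and a 1.2-fold higher number (0.09 log units; within the scatter) from compound 3 to compound 4, 1.4-fold (0.13 log units) apart, within the scatter of two such steps. Within the data shown here, neither step leaves the scatter, so the pair shows only that the change had no measurable effect in either surrounding, not that a larger effect would carry from one core to another.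

The compounds shown carry only hydroxy and methoxy groups on this aromatic ring. From the compounds shown here alone, whether an amine, a carboxylic acid or a longer alkoxy chain there would move the number beyond the scatter remains open.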